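This account rests on a few compounds, and the source may have more. Where it says the series, first, only, none or still open, it means among the compounds named here.

Compound 1 `COc1ccc2nc(C)cc(OCC(=O)Nc3ccccc3)c2c1` gives 118000 nM in an ADME assay on HepG2 cells (Homo sapiens) for cytotoxicity, read by trypan blue exclusion, with a stated time of 48 h, in the presence of a further agent that is not named here; on this read-out lower numbers stand for higher toxicity in this test and higher numbers for lower toxicity in this test. Compound 2 `COc1cccc(NC(=O)COc2cc(C)nc3ccc(OC)cc23)c1` gives 24700 nM. Compound 3 `COc1cc(NC(=O)COc2cc(C)nc3ccc(OC)cc23)cc(OC)c1` reaches only a limit of the test, > 131000 nM.

Compound 2 sits lowest of the two numbers shown; the gap to its nearest neighbour is a 4.8-fold lower number from compound 1 to compound 2 (0.68 log units; beyond the scatter). Compound 4 `COc1ccc2nc(C)cc(OCC(=O)Nc3ccccc3Cl)c2c1` has not been measured yet; its change from compound 2 is 2-chlorophenyl in place of 3-methoxyphenyl on an amide-type nitrogen. Going by the values given here, no measured step makes this exact change. The methoxy that now leaves was introduced in the step of a 4.8-fold lower number from compound 1 to compound 2 (0.68 log units; beyond the scatter), and a second methoxy produced an at least 5.3-fold higher number from compound 2 to compound 3 (0.72 log units; beyond the scatter), arriving at the limit of > 131000 nM in this assay, at which 1 of the 3 values shown sits. Removing that methoxy is expected to carry the number back toward compound 1, while the entering chlorine has no precedent among these compounds. Compound 4 is therefore estimated at 80000 nM, between 25000 nM and 131000 nM, meaning an expected step of a 3.2-fold higher number from compound 2 to compound 4 (0.51 log units; beyond the scatter).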

Compound 4, half-maximal cytotoxic concentration: > 140000 nM
Compound 4: no number, only a limit; the forecaster's own chance of this, stated with the estimate: 35%; middle value at least 1.7-fold (0.24 log units) away from the limit.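

On the amide-type nitrogen, 2-chlorophenyl in place of 3-methoxyphenyl gives an at least 5.6-fold higher number from compound 2 to compound 4 (0.75 log units; beyond the scatter), which leaves compound 2 with the lowest number of the four compounds in this assay. Chloro in place of hydrogen on an aromatic carbon gives an at least 1.1-fold higher number from compound 1 to compound 4 (0.07 log units; that floor lies within the scatter), so this step shows no readable change. Compound 4 gives only a limit, not a number: the limit of > 140000 nM in this assay, at which 1 of the 4 values shown sits.

Compound 3 and compound 4 both stand at limits, so they cannot be ranked against each other. As far as these compounds go, how an amine in place of the methoxy of compound 2 would read stays open.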